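A few compounds are considered here, and "the series" means these few. Any claim that something is new, unique, unknown or untested is made for them only; others in the source may bear on it.

Measured in a physicochemical assay for lipophilicity, using the shake flask method, in phosphate buffer, measured as octanol-water partition, at pH 7.4; a lower number here means a more polar compound, a higher number a more lipophilic compound:
compound 1 `Cc1cn([C@H]2CCCN([C@H](CC(C)C)c3ccc(C(=O)O)c(Oc4cccc(Cl)c4)c3F)C2)c(=O)[nH]c1=O` gives 0.92
compound 2 `Cc1cn([C@H]2CCCN([C@@H](CC(C)C)c3ccc(C(=O)O)c(Oc4cccc(Cl)c4)c3F)C2)c(=O)[nH]c1=O` gives 0.57
compound 3 `CC[C@@H](c1ccc(C(=O)O)c(Oc2cccc(Cl)c2)c1)N1CCC[C@H](n2cc(C)c(=O)[nH]c2=O)C1` gives 0.22

Compound 1 holds the highest of these three numbers, with compound 2 nearest and compound 3 furthest. Compound 4 `CCC[C@H](c1ccc(C(=O)O)c(Oc2cccc(Cl)c2)c1F)N1CCC[C@H](n2cc(C)c(=O)[nH]c2=O)C1` differs from compound 1 by one change: hydrogen in place of methyl on a saturated chain carbon bound to two saturated chain carbons (hydrogen in place of methyl on a saturated chain carbon bound to two saturated chain carbons, which reads isobutyl to propyl). Among the measured compounds shown here, the one measured step is a number 0.35 log units lower from compound 1 to compound 2 (beyond the scatter) and it bears only loosely because of the fact that compounds 1 and 2 differ only in the configuration as drawn and no measured step removes a methyl. Its size still serves as a guide, so a modest fall is expected in this assay for this change. The expected change is a number 0.32 log units lower from compound 1 to compound 4 (beyond the scatter) (an estimate). Compound 4 is estimated at 0.6 (expected range 0.25 to 0.95).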

Compound 4, distribution coefficient: 0.53
Compound 4: the middle estimate sits 0.07 log units above what was measured; measured number inside the range.
By their numbers in this assay, from the lowest: compound 3; then compounds 4 and 2 (each within the scatter of the next); then compound 1.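

In this assay, among the compounds shown here, the change from isobutyl to propyl gives the first measured step for a change in this chain: a number 0.39 log units lower from compound 1 to compound 4 (beyond the scatter). Removing this one methyl from a saturated chain carbon bound to two saturated chain carbons is therefore enough to move the number beyond the scatter. The earlier step could not show this, since it reflects configuration alone: the fact that compounds 1 and 2 differ only in the configuration as drawn

From the compounds shown here alone, a single step sets no trend along the chain, so the effect of a longer chain or of an amine at this place remains open. Also open, going by these compounds, is whether the same methyl removal gives a similar step in the opposite configuration at this carbon.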